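This account rests on a few compounds, and the source may have more. Where it says the series, first, only, none or still open, it means among the compounds named here.

Working notes on the series, all in a functional assay on HeLa cells (Homo sapiens) for inhibition, read by cell counting, with a stated time of 4 days; a higher number here means a weaker inhibitor, a lower number a stronger inhibitor.

Compound 2 `C=C(Br)C(=O)Nc1cccc(-c2cn3nc(-c4ccc(OCC)cc4)sc3n2)c1` gives 1100 nM. Compound 3 `C=C(Br)C(=O)Nc1cccc(-c2cn3nc(-c4cccc(OC)c4)sc3n2)c1` gives 1100 nM, the change from compound 2 being (3-methoxyphenyl in place of 4-ethoxyphenyl on an aromatic carbon), with no change at the digits printed from compound 2 to compound 3 (within the scatter). Compound 1 `CCOc1ccc(-c2nn3cc(-c4cccc(N)c4)nc3s2)cc1` gives 94000 nM, reached from compound 2 by hydrogen in place of (1-bromoethenyl)carbonyl on a nitrogen on an aromatic ring, with an 85-fold higher number from compound 2 to compound 1 (1.93 log units; beyond the scatter).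

Compound 4 `COc1cccc(-c2nn3cc(-c4cccc(N)c4)nc3s2)c1` is not yet measured; it is made from compound 3 by hydrogen in place of (1-bromoethenyl)carbonyl on a nitrogen on an aromatic ring. The place of this change matches that of the step to compound 1 word for word, so it is the same change set on the core of compound 3, the two cores differing by 3-methoxyphenyl in place of 4-ethoxyphenyl on an aromatic carbon.

Because an 85-fold higher number from compound 2 to compound 1 (1.93 log units; beyond the scatter) was large, the step to compound 4 is expected to be of similar size, an 82-fold higher number from compound 3 to compound 4 (1.91 log units; beyond the scatter). Compound 4 is estimated at 90000 nM in this assay, with a range from 30000 nM to 250000 nM.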

Compound 4, half-maximal inhibitory concentration: 230000 nM
Estimate against measurement, compound 4: 2.6-fold (0.41 log units) below, within the range that was stated.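

Hydrogen in place of (1-bromoethenyl)carbonyl on a nitrogen on an aromatic ring gives a 210-fold higher number from compound 3 to compound 4 (2.32 log units; beyond the scatter) in this assay. The change carries over between these two cores, and the sizes of the two steps cannot be told apart: the same change on two cores in this assay, an 85-fold higher number (1.93 log units; beyond the scatter) from compound 2 to compound 1 and a 210-fold higher number (2.32 log units; beyond the scatter) from compound 3 to compound 4, 2.4-fold (0.39 log units) apart, within the scatter of two such steps
Within the data shown here, this rests on only two matched pairs, and it does not show that the step holds on any other core, nor what lies behind it.

The compounds shown leave open whether the bromine or the rest of the acyl group accounts for the step, which a plain acetyl or an unbrominated propenoyl on the same nitrogen would help separate. Also open, as far as these compounds go, is whether the step holds with a carboxylic acid or a longer alkoxy chain on the aromatic ring.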